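Dimethyl Variant of a Pyrazolyl-Benzimidazole Series

This account rests on a few compounds, and the source may have more. Where it says the series, first, only, none or still open, it means among the compounds named here.

Measured compounds:
compound 1 `Clc1ccc(-c2nn(-c3ccccc3)cc2-c2nc3ccccc3[nH]2)cc1` — 1650 nM
compound 2 `Cc1ccc2[nH]c(-c3cn(-c4ccccc4)nc3-c3ccc(Cl)cc3)nc2c1` — 5360 nM
compound 3 `COc1ccc(-c2nn(-c3ccccc3)cc2-c2nc3cc(C)ccc3[nH]2)cc1` — 3290 nM

In a functional assay on HeLa cells (Homo sapiens) for antiproliferative activity, read by MTT assay, with a stated time of 48 h (a higher number here means a weaker inhibitor, a lower number a stronger inhibitor), compound 1 gives 1650 nM. Compound 2 carries methyl in place of hydrogen on an aromatic carbon and gives 5360 nM; the step is a 3.2-fold higher number from compound 1 to compound 2 (0.51 log units; beyond the scatter). Compound 3 differs from compound 2 by methoxy in place of chloro on an aromatic carbon. Compound 3 gives 3290 nM, a step of a 1.6-fold lower number from compound 2 to compound 3 (0.21 log units; within the scatter). The difference between the cores of compound 1 and compound 3 is not broken down here.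

Compound 4 `COc1ccc(-c2nn(-c3ccccc3)cc2-c2nc3cc(C)c(C)cc3[nH]2)cc1` is not yet measured. It differs from compound 3 by methyl in place of hydrogen on an aromatic carbon. Among the measured compounds shown here, this is the same kind of change as the one from compound 1 to compound 2, though not the same: in compound 4 the entering methyl sits ortho to a methyl group, which the earlier place lacked. For the measured compounds named here, only one earlier example of such a step exists, so the expectation rests on it alone. Compound 4 is expected to give a step of a 2.0-fold higher number from compound 3 to compound 4 (0.30 log units; within the scatter) in this assay, because the earlier methyl step gave a 3.2-fold higher number from compound 1 to compound 2 (0.51 log units; beyond the scatter). The estimate for compound 4 is 6500 nM, within 3000 nM to 14000 nM.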

Compound 4, half-maximal inhibitory concentration: 8930 nM
For compound 4 the middle estimate is 1.4-fold (0.14 log units) below the measured one, within the range that was stated.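

In this assay, methyl in place of hydrogen on an aromatic carbon again moves the result towards weaker inhibition, with a step of a 2.7-fold higher number from compound 3 to compound 4 (0.43 log units; beyond the scatter). Set beside the earlier case, the two steps agree: the same change on two cores in this assay, a 3.2-fold higher number (0.51 log units; beyond the scatter) from compound 1 to compound 2 and a 2.7-fold higher number (0.43 log units; beyond the scatter) from compound 3 to compound 4, 1.2-fold (0.08 log units) apart, within the scatter of two such steps The change therefore carries over with a similar size from the core of compound 1 to the core of compound 3, even though the entering methyl in compound 4 sits ortho to a methyl group, but two pairs show only this agreement and give neither a rule for other cores nor a reason for the weakening.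

The compounds shown leave open whether another group at this place, such as an ethyl chain, a fluorine atom or an amine, would shift the result in the same way. They also leave open how a carboxylic acid in place of the methoxy group would read in this assay.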